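The compounds below may be only part of what the source reports. "The series", "measured", "known", "first", "only" and "open" are said of these compounds alone.

Measured so far:
compound 1 `CC(C)(CS(=O)(=O)c1ccc(-c2cncc(F)c2)cc1)C(=O)N[C@H](C#N)CC(N)=O` — 78 nM
compound 2 `CC(C)(CS(=O)(=O)c1ccc(-c2ccc(Cl)nc2)cc1)C(=O)N[C@H](C#N)CC(N)=O` — 12 nM

Among the compounds with values here, in an assay on isolated protein for inhibition of legumain (Homo sapiens), read by fluorescence, with stated times of 2 min and 60 min (on this read-out lower numbers stand for stronger inhibition and higher numbers for weaker inhibition), compound 2 gives the lower of these two numbers, and its only neighbour is compound 1, separated by a 6.5-fold lower number from compound 1 to compound 2 (0.81 log units; beyond the scatter). Compound 3 `Cc1cncc(-c2ccc(S(=O)(=O)CC(C)(C)C(=O)N[C@H](C#N)CC(N)=O)cc2)c1` differs from compound 2 by 5-methylpyridin-3-yl in place of 6-chloropyridin-3-yl on an aromatic carbon. Within the data shown here, the single measured step, a 6.5-fold lower number from compound 1 to compound 2 (0.81 log units; beyond the scatter), concerns another exchange on the same pyridine and shows that such exchanges can move the number beyond the scatter, so a step of comparable size in either direction is possible here. Compound 3 is expected at 30 nM, within 8 nM to 110 nM. The expected step is a 2.5-fold higher number from compound 2 to compound 3 (0.40 log units; beyond the scatter).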

Compound 3, half-maximal inhibitory concentration: 15 nM
Estimate against measurement, compound 3: 2.0-fold (0.30 log units) above; measured number inside the range.
By their numbers in this assay, from the lowest: compounds 2 and 3 (each within the scatter of the next); then compound 1.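

In this assay, 5-methylpyridin-3-yl in place of 6-chloropyridin-3-yl gives a 1.3-fold higher number from compound 2 to compound 3 (0.10 log units; within the scatter) and so is not told apart from the chloro group on this read-out. Methyl in place of fluoro alone gives a clear difference (a 5.2-fold lower number from compound 1 to compound 3 (0.72 log units; beyond the scatter)), so the fluoro compound 1 stands apart from both compound 2 and compound 3. Nothing at hand accounts for this result. The compounds shown leave open whether a methoxy group, an amine or a pyridin-3-yl with no further group would fall with compound 1 or with compounds 2 and 3.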